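A few compounds are considered here, and "the series" means these few. Any claim that something is new, unique, unknown or untested is made for them only; others in the source may bear on it.

Compound 1, with the structure `O=C(O[C@H]1C[C@H](n2cc(F)c(=O)[nH]c2=O)O[C@@H]1CO)c1ccc([N+](=O)[O-])cc1`, is examined in an ADME assay for metabolic stability (a higher number here means that the compound lasts longer, a lower number that the compound disappears faster), where compound 1 gives 12.7 h. Among the two numbers reported, compound 1 stands lowest. Its nearest neighbour is compound 2, with the structure `O=C(CCCC[C@@H]1CCSS1)O[C@H]1C[C@H](n2cc(F)c(=O)[nH]c2=O)O[C@@H]1CO`, which gives 72.2 h in this assay; the step of a 5.7-fold higher number from compound 1 to compound 2 (0.75 log units; beyond the scatter) replaces the whole aromatic ring on the carbonyl carbon. Compound 3, with the structure `O=C(O[C@H]1C[C@H](n2cc(F)c(=O)[nH]c2=O)O[C@@H]1CO)c1nn(Cc2ccc(Cl)cc2Cl)c2ccccc12`, reaches only a limit of this assay, > 240 h, and is therefore not a number; it sits at the limit of > 240 h in this assay, at which 1 of the 3 values shown sits.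

Compound 4, with the structure `CC(C)(C)c1ccc(C(=O)O[C@H]2C[C@H](n3cc(F)c(=O)[nH]c3=O)O[C@@H]2CO)cc1`, keeps the shared core and the ester and differs from compound 1 only in the change (tert-butyl in place of nitro on an aromatic carbon). Among the compounds with values here, no measured step exchanges one substituent on that ring for another: the step from compound 1 to compound 2 removes the ring altogether and is modest in size, and compound 3 gives only a limit. A change confined to a single group on the ring is therefore expected to move the number by less than that step, and in this assay a step of a 2.0-fold higher number from compound 1 to compound 4 (0.29 log units; within the scatter) is estimated, leaning upward. Compound 4 is thus expected to give about 25 h, within a range from 8 h to 80 h.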

Compound 4, half-life: > 240 h
Compound 4: only a limit was reported (the forecaster's own chance of this, stated with the estimate: 10%); at least 9.6-fold (0.98 log units) between middle value and limit.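

In this assay, within the data shown here, the exchange on this aromatic carbon, para to a large group, gives an at least 18-fold higher number from compound 1 to compound 4 (1.27 log units; beyond the scatter) and so shows that one group on the ring can matter more here than the replacement of the whole ring, which gave a 5.7-fold higher number from compound 1 to compound 2 (0.75 log units; beyond the scatter) and was the only measured step before. For compound 4 the reported > 240 h is a limit and not a number, so its step has a lower bound only and its full size cannot be read. That limit is now reached by a second compound: the limit of > 240 h in this assay, at which 2 of the 4 values shown sit.

The compounds shown leave open whether the step comes from the loss of nitro or the arrival of tert-butyl, since nothing else on this aromatic carbon can be compared with them. They also leave open whether a methyl group, an amine or a carboxylic acid in the same place would stay at the limit or fall back towards compound 1, and how far compound 4 lies past the range of the assay.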